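Methyl on the Benzylamine Nitrogen of Compound 1

A few compounds are considered here, and "the series" means these few. Any claim that something is new, unique, unknown or untested is made for them only; others in the source may bear on it.

Measured compounds:
- Compound 1, `c1ccc(CNCC2CCN(CCCc3c[nH]c4ccc(-n5cnnc5)cc34)CC2)cc1`: 1.6 nM
- Compound 2, `c1ccc(C2CCCCN2C2CCN(CCCc3c[nH]c4ccc(-n5cnnc5)cc34)CC2)cc1`: 1.9 nM
- Compound 3, `CC(=O)Nc1ccc(CNC2CCN(CCCc3c[nH]c4ccc(-n5cnnc5)cc34)CC2)cc1`: 3 nM

All three share one core and were tested in an assay on CHO cells for displacement of a labelled ligand from 5-hydroxytryptamine receptor 1D (Homo sapiens); on this read-out higher numbers stand for weaker inhibition and lower numbers for stronger inhibition. Compound 1 shows the lowest of the three numbers, yet its gap to compound 2 and its gap to compound 3 both fall within the usual scatter, so no ranking among them can be drawn from these values.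

Compound 4, `CN(Cc1ccccc1)CC1CCN(CCCc2c[nH]c3ccc(-n4cnnc4)cc23)CC1`, is the next compound to be tested. It differs from compound 1 in one place: methyl in place of hydrogen on an amine nitrogen. Compound 2 already carries a tertiary amine at a comparable position of its side chain and remains close to compound 1, which suggests that a further substituent on that nitrogen need not cost binding.

Within the data shown here, no measured pair shows this exact step, so the expectation rests on the closeness of the three values. The step of a 1.3-fold higher number from compound 1 to compound 4 (0.10 log units; within the scatter) is expected to be small, in either direction, and not beyond the scatter. For compound 4 an estimate of 2 nM is expected, within a range of 0.8 nM to 5 nM, because compound 2 gives 1.9 nM with a tertiary amine in place.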

Compound 4, half-maximal inhibitory concentration: 0.9 nM
Estimate against measurement, compound 4: 2.2-fold (0.35 log units) above; measured number inside the range.
By their numbers in this assay, from the lowest: compounds 4, 1, 2 and 3 (each within the scatter of the next, the first and the last beyond it).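

Among these compounds, compound 4 gives the first direct reading of this position, since no earlier pair differed only on this amine nitrogen. In this assay, methyl in place of hydrogen gives a 1.8-fold lower number from compound 1 to compound 4 (0.25 log units; within the scatter), so the two compounds cannot be told apart, and the hydrogen on this nitrogen is not required for nanomolar numbers in this pair. No measurement shown here gives a reason for this result.

On these data alone, only the single methyl has been read at this nitrogen, so it remains open whether an ethyl, an isopropyl or an acetyl group there would keep the number in the same range. As far as these compounds go, it also remains open whether methyl would behave the same way on the amine nitrogen of compound 3, which has a different side chain.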